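A few compounds are considered here, and "the series" means these few. Any claim that something is new, unique, unknown or untested is made for them only; others in the source may bear on it.

Measured so far:
- compound 1 `CC(C)CCn1c(Cn2c(=O)n(C(C)C)c3ccccc32)nc2cc(C(C)(C)N)ccc21`: 3270 nM
- compound 2 `CC(C)CCn1c(Cn2c(=O)n(C(C)C)c3ccccc32)nc2cc(-c3ncon3)ccc21`: 223000 nM
- compound 3 `CC(C)CCn1c(Cn2c(=O)n(C(C)C)c3ccccc32)nc2cc(C(N)=O)ccc21`: 23400 nM

In an ADME assay on HEp-2 cells (Homo sapiens) for cytotoxicity (on this read-out higher numbers stand for lower toxicity in this test and lower numbers for higher toxicity in this test), compound 3 holds the middle of the three numbers. Compound 4 `CC(C)CCn1c(Cn2c(=O)n(C(C)C)c3ccccc32)nc2cc(N)ccc21` has amino in place of carbamoyl on an aromatic carbon. Two measured steps at this same place end at carbamoyl: a 7.2-fold higher number from compound 1 to compound 3 (0.85 log units; beyond the scatter) and a 9.5-fold lower number from compound 2 to compound 3 (0.98 log units; beyond the scatter). A third, a 68-fold higher number from compound 1 to compound 2 (1.83 log units; beyond the scatter), shows how widely this place can shift the number. Amino also forms part of the name of the 1-amino-1-methylethyl group in compound 1, which gives the lowest number, so a small move downward is expected. The expected change is a 2.0-fold lower number from compound 3 to compound 4 (0.29 log units; within the scatter). For compound 4 the estimated value is 12000 nM, with an expected range of 3500 nM to 45000 nM.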

Compound 4, half-maximal cytotoxic concentration: 32200 nM
Beside the measured number, compound 4's estimate is 2.7-fold (0.43 log units) below it, within the range that was stated.
By their numbers in this assay, from the lowest: compound 1; then compounds 3 and 4 (each within the scatter of the next); then compound 2.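

In this assay, replacing carbamoyl with amino leaves the number within the scatter, a 1.4-fold higher number from compound 3 to compound 4 (0.14 log units; within the scatter), so the smaller group gives no readable change here. Amino on the ring also differs clearly from the other two groups, with a 9.8-fold higher number from compound 1 to compound 4 (0.99 log units; beyond the scatter) and a 6.9-fold lower number from compound 2 to compound 4 (0.84 log units; beyond the scatter), so an amine nitrogen alone does not bring the low number seen with 1-amino-1-methylethyl. No measurement shown explains these differences. On these data alone, it remains open where aminomethyl, with one carbon carrying the amine, would fall, and how a carboxylic acid would read at this position.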